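This account rests on a few compounds, and the source may have more. Where it says the series, first, only, none or still open, it means among the compounds named here.

Series notes. The shared core carries an amide; compound 1 `O=C(Nc1ccc(Cl)c(-c2nnc3c(Cl)cccn23)c1)c1ccc(C(F)(F)F)cc1Cl`, compound 2 `O=C(Nc1ccc(Cl)c(-c2nnc3c(Cl)cccn23)c1)c1ccccn1` and compound 3 `O=C(Nc1ccc(Cl)c(-c2nnc3c(Cl)cccn23)c1)c1cccnc1` differ only in the group on the carbonyl carbon. In a functional assay on T47D cells (Homo sapiens) for antiproliferative activity, read by MTT assay, with a stated time of 72 h (on this read-out higher numbers stand for weaker inhibition and lower numbers for stronger inhibition), compound 1 gives > 100000 nM, which is a limit of the assay and not a number. Compound 2 gives > 100000 nM, again a limit. Compound 3 gives > 100000 nM, also a limit. Compound 2 therefore stands at the limit of > 100000 nM in this assay, at which 3 of the 3 values shown sit, with no read value of its own. Among the measured compounds shown here, the one single-point step in the set, a step that the two limits leave unreadable from compound 2 to compound 3, stays unreadable because of the limit of > 100000 nM in this assay, at which 3 of the 3 values shown sit.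

Compound 4 `Cc1cc(Cl)ccc1C(=O)Nc1ccc(Cl)c(-c2nnc3c(Cl)cccn23)c1` is not yet measured. Against compound 2 it shows (4-chloro-2-methylphenyl in place of pyridin-2-yl on a carbonyl carbon). For the measured compounds named here, no measured step bears on this change: the step from compound 2 to compound 3 cannot be read, and compound 1, which also carries a six-membered aromatic ring of carbon only on the carbonyl carbon, sits at the limit of > 100000 nM in this assay, at which 3 of the 3 values shown sit, too. No step beyond the scatter in this assay can be read from these data, so the expectation is that compound 4 stays at the limit as well. Compound 4 is estimated at 100000 nM, range 30000 nM to 300000 nM. The step from compound 2 to compound 4 is thus expected as a number no higher from compound 2 to compound 4 (the limit leaves the size open).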

Compound 4, half-maximal inhibitory concentration: > 100000 nM
Compound 4 was reported as a limit; the forecaster's own chance of this, stated with the estimate: 80%; the middle value lies on the limit itself.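

In this assay compound 4 gives > 100000 nM as a limit and not a number. Among the compounds shown here, no step from compound 2 or compound 3 to compound 4 can be read, because of one thing: the limit of > 100000 nM in this assay, at which 4 of the 4 values shown sit. The compounds shown leave open whether any group on the carbonyl carbon gives a read value in this assay on this shared core.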